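Furan for methoxyphenyl: a lipophilicity step carried over

A few compounds are considered here, and "the series" means these few. Any claim that something is new, unique, unknown or untested is made for them only; others in the source may bear on it.

Measured compounds:
- compound 1, `COc1ccc(-c2c(C#N)[n+]([O-])c3cc(F)c(F)cc3[n+]2[O-])cc1`: 2.09
- compound 2, `COc1ccc(-c2c(C#N)[n+]([O-])c3cc(Cl)c(Cl)cc3[n+]2[O-])cc1`: 2.33
- compound 3, `N#Cc1c(-c2ccco2)[n+]([O-])c2cc(F)c(F)cc2[n+]1[O-]`: 1.38

Of the compounds shown here, three of this study have been measured in a physicochemical assay for lipophilicity, measured as octanol-water partition; a lower number here means a more polar compound, a higher number a more lipophilic compound. Compound 1 gives 2.09 and compound 2 gives 2.33; these two values lie within the usual scatter of each other, so no order is read into them. The difference between the cores of compound 1 and compound 2 is not broken down here. Compound 3 gives 1.38, and the step of a number 0.71 log units lower from compound 1 to compound 3 (beyond the scatter) is the only measured one; the change behind it is furan-2-yl in place of 4-methoxyphenyl on an aromatic carbon.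

The unmeasured compound 4, `N#Cc1c(-c2ccco2)[n+]([O-])c2cc(Cl)c(Cl)cc2[n+]1[O-]`, is obtained from compound 2 by the same change, (furan-2-yl in place of 4-methoxyphenyl on an aromatic carbon). Because a number 0.71 log units lower from compound 1 to compound 3 (beyond the scatter) follows this same change, the partition coefficient of compound 4 is expected to fall by a step of similar size, a number 0.71 log units lower from compound 2 to compound 4 (beyond the scatter). On that basis compound 4 is estimated at 1.62, with a likely range from 1.3 to 1.95.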

Compound 4, partition coefficient: 1.64
Compound 4: middle estimate off by 0.02 log units, on the low side, within the range that was stated.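

In this assay, furan-2-yl in place of 4-methoxyphenyl on an aromatic carbon gives a number 0.69 log units lower from compound 2 to compound 4 (beyond the scatter) and, on the other core, a number 0.71 log units lower from compound 1 to compound 3 (beyond the scatter); the two steps are close in size, so for these two pairs the change carried over from one core to the other. Within the data shown here, this rests on only two pairs with the change at the same place, and it does not show that a step of this size would hold on any core beyond those of these four compounds. Nothing given here accounts for why the step kept its size.

The compounds shown leave open how the partition coefficient would move with a different group on that aromatic carbon, such as an amine or a carboxylic acid, in place of 4-methoxyphenyl. They also leave open whether the furan-2-yl step would keep its size on a core with a methyl ester in place of the cyano group.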